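Two Triazole Aryl Variants Both Beyond the Assay Limit

The source may report more compounds than this note shows. Statements on the series, on what has been measured and on what is new or still open speak of the compounds shown alone.

Compound 1 `C=C1C[C@]23C[C@@]1(O)CC[C@@H]2c1cccc(C)c1[C@@H]3Cn1cc(-c2ccc(OC)cc2)nn1` carries a 4-methoxyphenyl group on its triazole ring. In a functional assay on SW480 cells (Homo sapiens) for cytotoxicity, read by MTT assay, with a stated time of 4 days (on this read-out lower numbers stand for stronger inhibition and higher numbers for weaker inhibition), compound 1 gives > 20000 nM, which is a limit of the assay and not a number. Compound 2 `C=C1C[C@]23C[C@@]1(O)CC[C@@H]2c1cccc(C)c1[C@@H]3Cn1cc(-c2ccccn2)nn1` carries a pyridin-2-yl group in the same position. In this assay compound 2 gives > 20000 nM, again a limit and not a number. The step that the two limits leave unreadable from compound 1 to compound 2 therefore cannot be read, and compound 2 stands at the limit, as does every value shown (the limit of > 20000 nM in this assay, at which 2 of the 2 values shown sit). Compound 3 `C=C1C[C@]23C[C@@]1(O)CC[C@@H]2c1cccc(C)c1[C@@H]3Cn1cc(-c2ccccc2)nn1` differs from compound 2 by phenyl in place of pyridin-2-yl on an aromatic carbon. Within the data shown here, no measured step can tell what size to expect for this change, since the only step recorded is unreadable. Compound 3 is expected to give roughly 30000 nM, within a range from 8000 nM to 100000 nM, most likely again only as a limit. The expected step from compound 2 to compound 3 is thus a step that the limit leaves unreadable from compound 2 to compound 3, with no direction claimed beyond scatter.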

Compound 3, half-maximal inhibitory concentration: > 20000 nM
Compound 3: no number, only a limit; the forecaster's own chance of this, stated with the estimate: 80%; the middle value does not contradict the limit.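

The steps among compound 1, compound 2 and compound 3 cannot be read, since all three stand at one limit and give no number: the limit of > 20000 nM in this assay, at which 3 of the 3 values shown sit. Going by these compounds, how far each compound lies past that limit in this assay, and whether the 4-methoxyphenyl, pyridin-2-yl and phenyl groups differ at all, stays open.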